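The source may report more compounds than this note shows. Statements on the series, on what has been measured and on what is new or still open speak of the compounds shown alone.

Of the compounds shown here, three have been tested so far in a functional assay on HFF cells (Homo sapiens) for cytotoxicity; a higher number here means a weaker inhibitor, a lower number a stronger inhibitor. Compound 1 `N#Cc1nnc2nc[nH]c(N)c1-2` gives only a limit of the assay, > 100000 nM. Compound 2 `CC(=O)OCCOCn1nc(C#N)c2c(N)ncnc21` likewise gives only a limit, > 100000 nM. Compound 3 `COC(=N)c1nn(COCCO)c2ncnc(N)c12` again gives only a limit, > 100000 nM. Going by the values given here, no compound in the set therefore has a number of its own; where compound 3 stands can be said only as the limit of > 100000 nM in this assay, at which 3 of the 3 values shown sit, so it cannot be ranked against compound 1 or compound 2 beyond sharing that limit. Among the compounds with values here, no step between two measured compounds differing in a single place is available.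

Compound 4 `NC(=S)c1nn(COCCO)c2ncnc(N)c12` has not yet been measured. It differs from compound 3 by a group of 3 heavy atoms (1 carbon, 1 nitrogen, 1 sulfur; no ring) in place of a group of 4 heavy atoms (2 carbon, 1 nitrogen, 1 oxygen; no ring), on an aromatic carbon, so the change concerns the substituent on the five-membered ring, with the (2-hydroxyethoxy)methyl group and the rest of the shared core left in place. With every value shown sitting at the same limit, no direction of change can be derived from the measured compounds. Compound 4 is expected to sit at the limit as well, and the step that the limit leaves unreadable from compound 3 to compound 4 is expected to be none beyond the scatter. Compound 4 is estimated at 150000 nM in this assay, with a range from 60000 nM to 500000 nM.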

Compound 4, half-maximal inhibitory concentration: 55000 nM
Estimate against measurement, compound 4: 2.7-fold (0.44 log units) above; the measured number lies below the stated range.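

In this assay, going by these compounds alone, compound 4 gives 55000 nM, the first value in the set that is a number and not a limit, so a substituent on this aromatic carbon can bring the cytotoxicity read-out within the range of the assay while the (2-hydroxyethoxy)methyl group and the rest of the shared core stay in place. From the compounds shown here alone, exchanging the group of 4 heavy atoms for the sulfur-bearing group of 3 heavy atoms gives an at least 1.8-fold lower number from compound 3 to compound 4 (0.25 log units; that floor lies within the scatter), which is only a floor, so the true size of the step is unknown and this floor alone does not establish a change beyond the scatter. Compound 4 is the only compound in the set that stands off the shared limit: the limit of > 100000 nM in this assay, at which 3 of the 4 values shown sit.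

The compounds shown leave open whether a carboxamide, a carboxylic acid or an amine on this same aromatic carbon would also give a number of its own, or whether one is seen only with the sulfur-bearing group. They also leave open what the sulfur-bearing group would give on the core without the (2-hydroxyethoxy)methyl group.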